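Compound 3: a larger group on the methylamino nitrogen

The compounds below may be only part of what the source reports. "The series", "measured", "known", "first", "only" and "open" are said of these compounds alone.

In a functional assay on SF-268 cells (Homo sapiens) for cytotoxicity, read by MTT assay, with a stated time of 3 days (on this read-out higher numbers stand for weaker inhibition and lower numbers for stronger inhibition), compound 1 `N#Cc1c(Cl)nc(SCc2nc3ccccc3[nH]2)nc1-c1ccccc1` gives 3.2 nM and compound 2 `CNc1nc(SCc2nc3ccccc3[nH]2)nc(-c2ccccc2)c1C#N` gives 3.2 nM as well, so compound 2 stands level with compound 1. Compound 3 `N#Cc1c(NNC(N)=S)nc(SCc2nc3ccccc3[nH]2)nc1-c1ccccc1` is not yet measured. It loses the methyl of compound 2 and carries a larger group in its place, on a nitrogen on an aromatic ring (a group of 4 heavy atoms (1 carbon, 2 nitrogen, 1 sulfur; no ring) in place of one carbon atom, on a nitrogen on an aromatic ring). Among the compounds with values here, the one measured step that bears on this, no change at the digits printed from compound 1 to compound 2 (within the scatter) with methylamino in place of chloro on an aromatic carbon, shows nothing beyond the scatter. Within the data shown here, no measured compound carries the entering group, so this single step is thin support. No shift beyond the scatter is expected in this assay in either direction. The expected size is a 1.3-fold higher number from compound 2 to compound 3 (0.10 log units; within the scatter) for this change. The estimate for compound 3 is 4 nM with an expected range (1 nM to 30 nM).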

Compound 3, half-maximal inhibitory concentration: 3.37 nM
The estimate for compound 3 lay 1.2-fold (0.07 log units) above the measured number; low and high end bracket the measured number.
By their numbers in this assay, from the lowest: compounds 1, 2 and 3 (each within the scatter of the next).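

In this assay, a group of 4 heavy atoms (1 carbon, 2 nitrogen, 1 sulfur; no ring) in place of the methyl, on a nitrogen on an aromatic ring, gives a 1.1-fold higher number from compound 2 to compound 3 (0.02 log units; within the scatter), so a larger group on this nitrogen has not moved the read-out beyond the scatter. Set against the chloro compound, the larger group in place of one chlorine atom, on an aromatic carbon, gives a 1.1-fold higher number from compound 1 to compound 3 (0.02 log units; within the scatter), which extends the flat result from methylamino to a larger entering group carrying sulfur. Nothing on hand explains this flat read-out.

On these data alone, whether a longer alkyl chain such as butyl, or a benzyl group, on this nitrogen stays level remains open. So does the outcome with a carboxylic acid on the aromatic carbon in place of the chlorine.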